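Tetrazole in place of methoxypyridine on the shared core

A few compounds are considered here, and "the series" means these few. Any claim that something is new, unique, unknown or untested is made for them only; others in the source may bear on it.

Measured so far:
Compound 1 `O=C(CCCCCCc1ccccc1)c1ncc(-c2ccc(F)cc2)o1` gives 62 nM in an assay (Rattus norvegicus) for inhibition of Fatty-acid amide hydrolase 1 (Homo sapiens); on this read-out higher numbers stand for weaker inhibition and lower numbers for stronger inhibition.
Compound 2 `COc1ccnc(-c2cnc(C(=O)CCCCCCc3ccccc3)o2)c1` gives 0.8 nM in this assay.

Compound 2 stands lowest of the two numbers, and its nearest neighbour is compound 1, which lies a 78-fold lower number from compound 1 to compound 2 (1.89 log units; beyond the scatter). Compound 3 `O=C(CCCCCCc1ccccc1)c1ncc(-c2nnn[nH]2)o1` differs from compound 2 in one place: 1H-tetrazol-5-yl in place of 4-methoxypyridin-2-yl on an aromatic carbon.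

Among the measured compounds shown here, no measured step replaces this group with a tetrazole, so the expectation rests on weaker ground. For the measured compounds named here, the one step that bears on the same position, a 78-fold lower number from compound 1 to compound 2 (1.89 log units; beyond the scatter), shows that the group sitting there can move the number a great deal. Since the group entering in compound 3 looks quite unlike the group that gave compound 2 its low number, an upward move is expected for compound 3, of about a 38-fold higher number from compound 2 to compound 3 (1.57 log units; beyond the scatter), with wide uncertainty in either direction. Compound 3 is therefore estimated at 30 nM, within a range from 3 nM to 300 nM.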

Compound 3, inhibition constant: 63 nM
The estimate for compound 3 lay 2.1-fold (0.32 log units) below the measured number, and the stated range covers the measured number.
By their numbers in this assay, from the lowest: compound 2; then compounds 1 and 3 (each within the scatter of the next).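

Replacing the 4-methoxypyridin-2-yl group with 1H-tetrazol-5-yl gives a much weaker reading (a 79-fold higher number from compound 2 to compound 3 (1.90 log units; beyond the scatter)), so a ring containing nitrogen is not enough at this position to match compound 2. Two very different rings can also read alike here: 1H-tetrazol-5-yl and 4-fluorophenyl show no real difference (a 1.0-fold higher number from compound 1 to compound 3 (0.01 log units; within the scatter)), leaving 4-methoxypyridin-2-yl alone among these three groups in giving the low number. No measurement shown here explains why these groups behave as they do.

Going by these compounds, it remains open whether the ring nitrogen, the methoxy group or the two together set compound 2 apart. A plain pyridin-2-yl group and a 4-methoxyphenyl group at the same carbon would separate those two parts.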